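From cyclohexyl to 2-ethoxyphenyl on the shared core

The compounds below may be only part of what the source reports. "The series", "measured", "known", "first", "only" and "open" are said of these compounds alone.

Compound 1 `CCCc1ccc(NC2=CC(=O)c3c(nc4n3[C@H]3OC[C@@H](O)[C@H]3OC4)C2=O)cc1`: > 4000 nM (a limit)
Compound 2 `O=C1C(NC2CCCCC2)=CC(=O)c2c1nc1n2[C@H]2OC[C@@H](O)[C@H]2OC1`: > 16000 nM (a limit)

In a functional assay on ECa-109 cells for inhibition, with ECa-109 cell line (Homo sapiens) as the target, read by sulforhodamine B assay (a higher number here means a weaker inhibitor, a lower number a stronger inhibitor), compound 2 has no exact number, only the limit > 16000 nM. The other measured compound offers no firmer footing, since compound 1 also has only a limit, > 4000 nM.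

The next compound, compound 3 `CCOc1ccccc1NC1=CC(=O)c2c(nc3n2[C@H]2OC[C@@H](O)[C@H]2OC3)C1=O`, keeps the shared core and changes one group: 2-ethoxyphenyl in place of cyclohexyl on an amine nitrogen. In words, this puts 2-ethoxyphenyl in place of cyclohexyl on an amine nitrogen.

Among the compounds with values here, one measured step bears on this change, a step that the two limits leave unreadable from compound 1 to compound 2. It also swaps between cyclohexyl and a substituted phenyl group on that nitrogen, but two limits give it no readable size, so no size can be carried over. Compound 1, the 4-propylphenyl member, has the limit > 4000 nM, which gives only a slight reason to lean toward stronger inhibition. A modest at least 2.0-fold lower number from compound 2 to compound 3 (0.30 log units; that floor lies within the scatter) is therefore expected, and this is a rough estimate. For compound 3 the estimated value is 8000 nM, with an expected range from 2000 nM to 30000 nM.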

Compound 3, half-maximal inhibitory concentration: 4320 nM
Compound 3: middle estimate off by 1.9-fold (0.27 log units), on the high side; low and high end bracket the measured number.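

Compound 2 has only a limit in this assay, > 16000 nM, so its true value is not known. Even so, putting 2-ethoxyphenyl in place of cyclohexyl on the amine nitrogen brings an at least 3.7-fold lower number from compound 2 to compound 3 (0.56 log units; beyond the scatter), the first step among these compounds with a readable size, and it shows that the number in this assay does respond to the group on this nitrogen. The steps that involve compound 1 cannot be read, so the compounds shown do not settle how 2-ethoxyphenyl compares with 4-propylphenyl.

The readable step swaps a non-aromatic ring of carbon for an aromatic one and also adds the ethoxy group, and the compounds shown cannot separate these two parts of the change; a plain phenyl group on the same nitrogen would be the direct way to tell them apart. From the compounds shown here alone, it also remains open how this nitrogen would tolerate a group of a different kind, such as a methoxyphenyl group with a shorter chain or a phenyl ring carrying a carboxylic acid.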